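This account rests on a few compounds, and the source may have more. Where it says the series, first, only, none or still open, it means among the compounds named here.

Measured so far:
compound 1 `COC(=O)N1CCC(Oc2ncnc(Oc3ccc(/C=C4\SC(=O)NC4=O)cc3)c2C)CC1` — 1410 nM
compound 2 `CC(C)COC(=O)N1CCC(Oc2cc(Oc3ccc(/C=C4\SC(=O)NC4=O)cc3)ncn2)CC1` — 745 nM
compound 3 `COC(=O)N1CCC(Oc2ncnc(Oc3cccc(/C=C4\SC(=O)NC4=O)c3)c2C)CC1` — "not active" (no number reported)

In a functional assay on CHO-K1 cells for agonist activity at Glucose-dependent insulinotropic receptor (Homo sapiens), read by cAMP accumulation and immunoassay, with a stated time of 1 h (on this read-out higher numbers stand for an effect only at larger amounts of compound and lower numbers for an effect already at smaller amounts), compound 1 gives 1410 nM and compound 2 gives 745 nM. Compound 3 carries the arylidene thiazolidinedione on a different position of the phenoxy ring than compound 1, and in this assay compound 3 is reported as "not active" (no number reported), so no single number stands for it; it sits at the weak end of the series, with nothing quantified to build on.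

Compound 4 `Cc1c(Oc2cccc(/C=C3\SC(=O)NC3=O)c2)ncnc1OC1CCN(C(=O)OCc2ccccc2)CC1` is the next step from compound 3. The change is phenyl in place of hydrogen on a saturated chain carbon bound to an oxygen next to a carbonyl group. Going by the values given here, no measured pair shows what this carbamate enlargement does, so no step size is known from the data; a change at this remote end of the molecule is expected to move potency at most modestly, in either direction, and most likely not beyond the scatter. Given that compound 3 is "not active" (no number reported), compound 4 is expected to stay weak, with a fair chance of again returning no number. The estimate for compound 4 in this assay is 10000 nM, with a range of 2000 nM to 50000 nM.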

Compound 4, half-maximal effective concentration: 106 nM
Compound 4: middle estimate off by 94-fold (1.97 log units), on the high side; the measured number lies below the stated range.
By their numbers in this assay, from the lowest: compound 4; then compounds 2 and 1 (each within the scatter of the next).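

Compound 3 has no number in this assay and compound 4 gives 106 nM, so the change from methoxycarbonyl to benzyloxycarbonyl yields no readable step. The compounds shown leave open what that change does on the core of compound 1. No evidence bearing on a cause is available.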